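The compounds below may be only part of what the source reports. "The series", "measured", "known", "first", "only" and "open" are said of these compounds alone.

Compound 1 `CC(C)(C)OC(=O)Nc1ncc(C(Oc2ccc3cc(Br)ccc3c2)c2ccc(Cl)cc2)s1`: in an ADME assay on HepG2 2.2.15 cells (Homo sapiens) for cytotoxicity (on this read-out higher numbers stand for lower toxicity in this test and lower numbers for higher toxicity in this test), compound 1 gives > 50000 nM, which is a limit of the test rather than a number.
Compound 2 `O=C(Nc1ncc(C(Oc2ccc3cc(Br)ccc3c2)c2ccc(Cl)cc2)s1)c1cc(F)c(F)cc1F`: compound 2 is reported in this assay as "not toxic" (no number reported), with no number attached.
Compound 3 `CCc1ccc(S(=O)(=O)Nc2ncc(C(Oc3ccc4cc(Br)ccc4c3)c3ccc(Cl)cc3)s2)cc1`: compound 3 gives > 50000 nM in this assay, again a limit of the test.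

Compound 3 therefore stands at the ceiling of this assay, and the limit of > 50000 nM in this assay, at which 2 of the 3 values shown sit, describes that ceiling. For the measured compounds named here, the one step between measured compounds, a step that the two limits leave unreadable from compound 1 to compound 3, has both ends at that limit and so offers no readable size. Compound 4 `Cc1ccc(S(=O)(=O)Nc2ncc(C(Oc3ccc4cc(Br)ccc4c3)c3ccc(Cl)cc3)s2)c2ccccc12` differs from compound 3 by 4-methylnaphthalen-1-yl in place of 4-ethylphenyl on a sulfonyl sulfur. Going by the values given here, no measured step speaks to this change, so no movement beyond the scatter is expected in this assay, and compound 4 is expected to sit at the same limit, an expected step that the limit leaves unreadable from compound 3 to compound 4. The estimate for compound 4 is 60000 nM, with a range from 20000 nM to 150000 nM.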

Compound 4, half-maximal cytotoxic concentration: > 50000 nM
Compound 4 ended at the assay's limit; the forecaster's own chance of this, stated with the estimate: 85%; the middle value is on the limit's open side.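

Compound 3 and compound 4 both sit at the limit of this assay, so the step between them cannot be read. The compounds shown leave open whether any group on the sulfonyl sulfur gives a measurable toxic concentration.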